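A few compounds are considered here, and "the series" means these few. Any claim that something is new, unique, unknown or untested is made for them only; others in the source may bear on it.

Compound 3 `C/C=C1/[C@H](O[C@@H]2O[C@H](CO)[C@@H](O)[C@H](O)[C@H]2O)OC=C(C(=O)OC)[C@H]1CC(=O)OCCCc1ccc(OC)c(OC)c1`, compound 4 `C/C=C1/[C@H](O[C@@H]2O[C@H](CO)[C@@H](O)[C@H](O)[C@H]2O)OC=C(C(=O)OC)[C@H]1CC(=O)OCCc1ccc([N+](=O)[O-])cc1`, and the two related compounds, compound 1 `C/C=C1/[C@H](O[C@@H]2O[C@H](CO)[C@@H](O)[C@H](O)[C@H]2O)OC=C(C(=O)OC)[C@H]1CC(=O)O` and compound 2 `C/C=C1/[C@H](O[C@@H]2O[C@H](CO)[C@@H](O)[C@H](O)[C@H]2O)OC=C(C(=O)OC)[C@H]1CC(=O)OCCCC`, share one core and differ only in the group on the oxygen next to a carbonyl group. In a functional assay on SK-BR-3 cells (Homo sapiens) for antiproliferative activity, read by MTT assay, with a stated time of 72 h (on this read-out higher numbers stand for weaker inhibition and lower numbers for stronger inhibition), compound 1 gives only the limit > 15000 nM. In this assay compound 2 likewise gives only the limit > 15000 nM. In this assay compound 3 also gives only the limit > 20000 nM. The change from compound 3 to compound 4 is 4-nitrophenyl in place of 3,4-dimethoxybenzyl on a saturated chain carbon, two bonds along the chain from an oxygen next to a carbonyl group. Within the data shown here, the step that the two limits leave unreadable from compound 1 to compound 2 and the step that the two limits leave unreadable from compound 2 to compound 3 have no readable size, so no measured step gives a direction for this change. For compound 4 the expected step is a number no higher from compound 3 to compound 4 (the limit leaves the size open), nothing beyond the scatter. Compound 4 is estimated at 20000 nM, within 8000 nM to 50000 nM.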

Compound 4, half-maximal inhibitory concentration: > 20000 nM
Compound 4 was reported as a limit; the forecaster's own chance of this, stated with the estimate: 85%; the middle value lies on the limit itself.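

Among these compounds, compound 4, like compound 1, compound 2 and compound 3, gives only a limit, so no step between compound 4 and any of them can be read. The compounds shown leave open how these four rank against one another.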